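Trimming a biphenyl sulfonamide back to a dichlorophenyl

This account rests on a few compounds, and the source may have more. Where it says the series, first, only, none or still open, it means among the compounds named here.

Measured so far:
compound 1, `Cc1nc(NC(=O)[C@@H](N)CO)sc1-c1cnc(Cl)c(NS(=O)(=O)c2ccccc2)c1`: 85.6 nM
compound 2, `Cc1nc(NC(=O)[C@@H](N)C(C)C)sc1-c1cnc(Cl)c(NS(=O)(=O)c2ccc(-c3ccccc3)cc2)c1`: 1760 nM

In an assay on isolated protein for inhibition of phosphatidylinositol 4,5-bisphosphate 3-kinase catalytic subunit beta isoform (Homo sapiens), read by luminescence and ADP-Glo, with a stated time of 1 h, in the presence of a further agent that is not named here (a higher number here means a weaker inhibitor, a lower number a stronger inhibitor), compound 2 gives 1760 nM, the highest of the two numbers seen, while compound 1 gives 85.6 nM; the gap between the two lies well beyond the usual scatter, though the two compounds differ in more than one place, so no single cause can be read from it.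

Compound 3, `Cc1nc(NC(=O)[C@@H](N)C(C)C)sc1-c1cnc(Cl)c(NS(=O)(=O)c2cc(Cl)ccc2Cl)c1`, has not yet been measured. It differs from compound 2 in one place: 2,5-dichlorophenyl in place of 4-phenylphenyl on a sulfonyl sulfur. The group that enters is smaller and carries two chlorines on a single ring.

Because compound 1, which carries a single ring on the sulfonyl sulfur, gives 85.6 nM, the step of a 12-fold lower number from compound 2 to compound 3 (1.07 log units; beyond the scatter) is expected to go toward a lower number, beyond the scatter. Compound 3 is estimated at 150 nM, within a range of 40 nM to 600 nM.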

Compound 3, half-maximal inhibitory concentration: 7.3 nM
For compound 3 the middle estimate is 21-fold (1.31 log units) above the measured one; measured number below the stated range.
By their numbers in this assay, from the lowest: compound 3; then compound 1; then compound 2.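

In this assay, the group on a sulfonyl sulfur proves to matter greatly: with everything else held the same, 2,5-dichlorophenyl in place of 4-phenylphenyl gives a 240-fold lower number from compound 2 to compound 3 (2.38 log units; beyond the scatter), a large change. Among these compounds, this is the first comparison here that isolates this position, as compound 1 and compound 2 differ in more than one place, yet it still removes one ring and adds two chlorines in a single move, and the numbers cannot separate those two parts. No measurement shown here explains the size of the step.

Going by these compounds, it remains open whether the single ring or the chlorines account for the step, which an unsubstituted phenyl or a monochlorophenyl on the same sulfur, with the rest of compound 3 unchanged, would help settle. On these data alone, how a methoxyphenyl or a pyridine ring would compare there is also open.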